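Four Related Compounds Tested for Cytotoxicity

The source may hold more compounds than are shown below. What is called first, only, known or untested is meant among the compounds shown, and "the series" means these compounds.

Compound 1 `O=S(=O)(c1ccccc1)c1nc2ccccc2nc1Nc1ccc(Cl)cc1` is measured in a functional assay on KB cells (Homo sapiens) for cytotoxicity, read by MTT assay, with a stated time of 72 h (a higher number here means a weaker inhibitor, a lower number a stronger inhibitor), where compound 1 gives 41200 nM. Compound 2 `O=S(=O)(c1ccccc1)c1nc2ccccc2nc1Nc1ccc(C(F)(F)F)cc1` carries the change (trifluoromethyl in place of chloro on an aromatic carbon); in this assay compound 2 reaches only a limit of the assay, > 50000 nM. That change gave an at least 1.2-fold higher number from compound 1 to compound 2 (0.08 log units; that floor lies within the scatter), and the limit of > 50000 nM in this assay, at which 1 of the 3 values shown sits, marks where that limit sits. Compound 3 `Cc1ccc(S(=O)(=O)c2nc3ccccc3nc2Nc2ccc(Cl)cc2)cc1` differs from compound 1 by methyl in place of hydrogen on an aromatic carbon, and in this assay compound 3 gives 13800 nM, which is a 3.0-fold lower number from compound 1 to compound 3 (0.48 log units; beyond the scatter). Compound 4 `Cc1ccc(S(=O)(=O)c2nc3ccccc3nc2Nc2ccc(C(F)(F)F)cc2)cc1` has not yet been measured; it differs from compound 3 by trifluoromethyl in place of chloro on an aromatic carbon, the same change as from compound 1 to compound 2. For compound 4 in this assay a step of a 2.5-fold higher number from compound 3 to compound 4 (0.40 log units; beyond the scatter) is expected, resting on the earlier step of an at least 1.2-fold higher number from compound 1 to compound 2 (0.08 log units; that floor lies within the scatter). Compound 4 is therefore estimated at 35000 nM, between 15000 nM and 80000 nM, with a real chance that only a limit is reported.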

Compound 4, half-maximal inhibitory concentration: 10300 nM
Compound 4: middle estimate off by 3.4-fold (0.53 log units), on the high side; measured number below the stated range.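

In this assay, trifluoromethyl in place of chloro gives a 1.3-fold lower number from compound 3 to compound 4 (0.13 log units; within the scatter), so on the methyl-bearing core this change shows no effect beyond the scatter, and whether it behaves alike on both cores cannot be settled: the same change on two cores in this assay, an at least 1.2-fold higher number (0.08 log units; that floor lies within the scatter) from compound 1 to compound 2 and a 1.3-fold lower number (0.13 log units; within the scatter) from compound 3 to compound 4; the limit leaves it open whether they differ
Compound 2 gives only a limit of the assay, > 50000 nM.
Methyl in place of hydrogen gives an at least 4.8-fold lower number from compound 2 to compound 4 (0.68 log units; beyond the scatter), so this change lowers the number on both cores, although the size of that lowering cannot be compared exactly: the same change on two cores in this assay, a 3.0-fold lower number (0.48 log units; beyond the scatter) from compound 1 to compound 3 and an at least 4.8-fold lower number (0.68 log units; beyond the scatter) from compound 2 to compound 4; the limit leaves it open whether they differ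

These four compounds cover only chloro, trifluoromethyl, hydrogen and methyl at the two changed places. Going by these compounds, whether an amine in place of chloro, or a methoxy group or a carboxylic acid in place of methyl, would follow the same pattern remains open.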